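A halogen returns to the aryl group on the core

The source may report more compounds than this note shows. Statements on the series, on what has been measured and on what is new or still open speak of the compounds shown alone.

Of the compounds shown here, three sharing a common core have been measured in a functional assay on L1210 cells (Mus musculus) for inhibition, read by cell counting, with a stated time of 2 days; on this read-out higher numbers stand for weaker inhibition and lower numbers for stronger inhibition. Compound 1 `C=C(Br)C(=O)Nc1cccc(-c2cn3nc(-c4ccc(F)cc4)sc3n2)c1`, which carries a 4-fluorophenyl group, gives 250 nM. Compound 2 `C=C(Br)C(=O)Nc1cccc(-c2cn3nc(-c4ccccc4)sc3n2)c1`, with an unsubstituted phenyl, gives 600 nM, and compound 3 `C=C(Br)C(=O)Nc1cccc(-c2cn3nc(-c4cccc(OC)c4)sc3n2)c1`, with a 3-methoxyphenyl, gives 580 nM. Compound 3 thus stands second highest of the three numbers; its value sits within the scatter of compound 2, while a 2.3-fold higher number from compound 1 to compound 3 (0.37 log units; beyond the scatter).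

The step now taken leads from compound 3 to compound 4 `C=C(Br)C(=O)Nc1cccc(-c2cn3nc(-c4ccc(Cl)cc4)sc3n2)c1`: 4-chlorophenyl in place of 3-methoxyphenyl on an aromatic carbon. Among the compounds with values here, no measured pair exchanges one halogen for another at this position, so the expectation rests on neighbouring steps. The step of a 2.3-fold higher number from compound 1 to compound 3 (0.37 log units; beyond the scatter) shows that removing the 4-fluorophenyl in favour of the 3-methoxyphenyl raised the number modestly, and a 2.4-fold higher number from compound 1 to compound 2 (0.38 log units; beyond the scatter) shows a similar rise when the fluoro was simply removed. Compound 4 resembles compound 1 in bearing a halogen on the 4-chlorophenyl, so the author expects the change to run back in the opposite direction, giving a 1.9-fold lower number from compound 3 to compound 4 (0.29 log units; within the scatter) in this assay.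

For compound 4 the estimated value in this assay is 300 nM, with a likely range from 120 nM to 800 nM.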

Compound 4, half-maximal inhibitory concentration: 1400 nM
For compound 4 the middle estimate is 4.7-fold (0.67 log units) below the measured one, and the stated range ends below it.
By their numbers in this assay, from the lowest: compound 1; then compounds 3 and 2 (each within the scatter of the next); then compound 4.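

In this assay, the two halogens on the phenyl group do not behave alike: going from fluoro to chloro gives a clear change (a 5.6-fold higher number from compound 1 to compound 4 (0.75 log units; beyond the scatter)), and the two sit on opposite sides of the unsubstituted phenyl, with fluoro lying lower (a 2.4-fold higher number from compound 1 to compound 2 (0.38 log units; beyond the scatter)) and chloro higher (a 2.3-fold higher number from compound 2 to compound 4 (0.37 log units; beyond the scatter)). Having a halogen on this aryl group therefore does not by itself bring the number down, and the 4-chlorophenyl also stands above the 3-methoxyphenyl (a 2.4-fold higher number from compound 3 to compound 4 (0.38 log units; beyond the scatter)), which makes compound 4 the weakest of the four and compound 1, with its 4-fluorophenyl, the strongest. Nothing available accounts for this difference between the two halogens.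

The compounds shown leave open whether the order seen here extends to a bromo group on the phenyl, or to an amine or a carboxylic acid there. They also leave open whether the gap between chloro and fluoro holds when the bromoacrylamide-bearing part of the shared core is changed, for example when bromo on that part gives way to hydrogen.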